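The source may hold more compounds than are shown below. What is called first, only, known or untested is meant among the compounds shown, and "the series" means these compounds.

In an ADME assay on Vero cells (Chlorocebus sabaeus) for cytotoxicity, read by MTT assay, with a stated time of 48 h (a higher number here means a weaker inhibitor, a lower number a stronger inhibitor), compound 3 `O=C(OC1CCC(CN2CCN(c3cc(=O)c4cc(C(F)(F)F)cc([N+](=O)[O-])c4s3)CC2)CC1)c1cccc(C(F)(F)F)c1` stands at > 64 ug/mL as a limit of the assay and not a number. Compound 2 `CCCC(=O)OC1CCC(CN2CCN(c3cc(=O)c4cc(C(F)(F)F)cc([N+](=O)[O-])c4s3)CC2)CC1`, with propylcarbonyl on the same oxygen, gives > 64 ug/mL and this too is only a limit. Compound 1 `O=c1cc(N2CCN(CC3CCC(OS(=O)(=O)c4cccnc4)CC3)CC2)sc2c([N+](=O)[O-])cc(C(F)(F)F)cc12`, with (pyridin-3-yl)sulfonyl on that oxygen, gives > 64 ug/mL as a limit as well. The whole record is therefore the limit of > 64 ug/mL in this assay, at which 3 of the 3 values shown sit, and no number is yet available for comparison.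

Compound 4 `CC(C)S(=O)(=O)OC1CCC(CN2CCN(c3cc(=O)c4cc(C(F)(F)F)cc([N+](=O)[O-])c4s3)CC2)CC1` carries isopropylsulfonyl in place of (3-(trifluoromethyl)phenyl)carbonyl on an oxygen on a saturated carbon, a change counted as isopropylsulfonyl in place of (3-(trifluoromethyl)phenyl)carbonyl on an oxygen on a saturated carbon in all.

Among the measured compounds shown here, three measured steps bear on this change: a step that the two limits leave unreadable from compound 1 to compound 2, a step that the two limits leave unreadable from compound 1 to compound 3 and a step that the two limits leave unreadable from compound 2 to compound 3. The closest is the second, which links a sulfonyl to the same carbonyl group, but none of the three has a size that can be read. They give no ground for expecting a change beyond the scatter in this assay in either direction.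

The expected change is a step that the limit leaves unreadable from compound 3 to compound 4 with no direction favoured. Compound 4 is estimated at 70 ug/mL, with an expected range from 40 ug/mL to 128 ug/mL, and it is expected most likely to be reported as a limit again.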

Compound 4, half-maximal inhibitory concentration: > 64 ug/mL
Compound 4 ended at the assay's limit; the forecaster's own chance of this, stated with the estimate: 85%; the middle value lies beyond the limit too.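

Among the compounds shown here, no step from compound 1, compound 2 or compound 3 to compound 4 can be read in this assay, since all four compounds rest on one and the same limit: the limit of > 64 ug/mL in this assay, at which 4 of the 4 values shown sit. The compounds shown leave open how far each lies from that limit, and whether the groups on the oxygen differ in this assay at all.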